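The compounds below may be only part of what the source reports. "The series", "measured", "known", "first", "only" and "open" are said of these compounds alone.

In a functional assay on Huh-5-2 cells (Homo sapiens), read by MTT assay (on this read-out higher numbers stand for lower toxicity in this test and lower numbers for higher toxicity in this test), compound 1 `NC(=O)c1ccc(-c2ccc(Cl)cc2COc2ccc(-c3nc4cc(C(=O)O)ccc4n3C3CCCCC3)cc2)cc1` gives > 50000 nM as a limit of the assay and not as a number. Compound 2 `Cc1nc(COc2ccc(-c3nc4cc(C(=O)O)ccc4n3C3CCCCC3)cc2)c(-c2ccc(Cl)cc2)o1` gives 39000 nM in this test, and compound 3 `O=C(O)c1ccc2c(c1)nc(-c1ccc(OCc3cc(C(=O)NCCO)ccc3-c3ccc(Cl)cc3)cc1F)n2C1CCCCC1` gives 26000 nM on the same read-out. These two numbers lie within the usual scatter of repeated measurements, so compound 3 cannot be separated from compound 2 and shares its place on the scale.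

Compound 4 `CC(=O)N(c1ccc(-c2ccc(Cl)cc2)c(COc2ccc(-c3nc4cc(C(=O)O)ccc4n3C3CCCCC3)c(F)c2)c1)C(C)C` has not been measured yet. It departs from compound 3 at one place, where acetyl(isopropyl)amino stands in place of (2-hydroxyethyl)carbamoyl on an aromatic carbon, para to a 4-chlorophenyl group acetyl(isopropyl)amino in place of (2-hydroxyethyl)carbamoyl on an aromatic carbon in the counted terms of that swap.

Going by the values given here, no two measured compounds differ at only one place, so the data give no direct size for a change of this kind. Among the compounds with values here, the only guide is that compound 2 at 39000 nM and compound 3 at 26000 nM stay close despite their different side groups. On that basis, the expected change a 1.1-fold lower number from compound 3 to compound 4 (0.03 log units; within the scatter) is no step beyond the scatter in either direction. For compound 4 the estimated half-maximal cytotoxic concentration is 24000 nM with an expected range of 10000 nM to 50000 nM in this test.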

Compound 4, half-maximal cytotoxic concentration: 20000 nM
Compound 4: the middle estimate sits 1.2-fold (0.08 log units) above what was measured; the measured number falls inside the stated range.
By their numbers in this assay, from the lowest: compounds 4, 3 and 2 (each within the scatter of the next). At a limit, above all of these: compound 1.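

In this assay, replacing (2-hydroxyethyl)carbamoyl with acetyl(isopropyl)amino on the aromatic carbon para to a 4-chlorophenyl group gives a 1.3-fold lower number from compound 3 to compound 4 (0.11 log units; within the scatter), the only step shown between two compounds that differ in one place. At this position, then, a swap from a group that carries hydrogen-bond donors to one that carries none, with no ring or net charge added, does not move the number beyond the scatter of repeated measurements. Compound 1 stands at a limit of the assay and not at a number, so it gives no size for any change: the limit of > 50000 nM in this assay, at which 1 of the 4 values shown sits.

A single step cannot show whether a different kind of group at this place, such as a primary amine, a sulfonamide or a longer chain ending in a tertiary amine, would shift the number beyond the scatter. It also leaves open whether the same swap would stay this small on a compound with a different core or at another aromatic carbon.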